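Hydroxyl Replacements on the Aryl Hydrazone of Compound 1

The source may report more compounds than this note shows. Statements on the series, on what has been measured and on what is new or still open speak of the compounds shown alone.

Measured compounds:
compound 1 `O=C(CSc1nnc(-c2ccncc2)o1)N/N=C/c1ccc([N+](=O)[O-])cc1` gives 31500 nM in a functional assay on BGC-823 cells (Homo sapiens) for cytotoxicity, read by MTT assay, with a stated time of 48 h; on this read-out higher numbers stand for weaker inhibition and lower numbers for stronger inhibition;
compound 2 `O=C(CSc1nnc(-c2ccncc2)o1)N/N=C/c1ccc(O)cc1` gives 7940 nM;
compound 3 `O=C(CSc1nnc(-c2ccncc2)o1)N/N=C/c1cc(Br)ccc1O` gives 9590 nM.

Compound 1 has the highest number of the three. The change to compound 4 `O=C(CSc1nnc(-c2ccncc2)o1)N/N=C/c1ccc(O)c(O)c1` is 3,4-dihydroxyphenyl in place of 4-nitrophenyl on a carbon with a double bond to nitrogen. Among the measured compounds shown here, two measured steps bear on it: a 4.0-fold lower number from compound 1 to compound 2 (0.60 log units; beyond the scatter) and a 3.3-fold lower number from compound 1 to compound 3 (0.52 log units; beyond the scatter), both putting a hydroxy-bearing ring in place of the nitrophenyl and both modest, beyond the scatter. The pair compound 2 and compound 3 shows a 1.2-fold higher number from compound 2 to compound 3 (0.08 log units; within the scatter), so a further ring substituent beside the hydroxy changed little. For compound 4 a similar step downward is therefore expected, a 4.2-fold lower number from compound 1 to compound 4 (0.62 log units; beyond the scatter). Compound 4 is estimated at 7500 nM, with a range from 3000 nM to 20000 nM.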

Compound 4, half-maximal inhibitory concentration: 1260 nM
The estimate for compound 4 lay 6.0-fold (0.77 log units) above the measured number, outside the stated range (below it).
By their numbers in this assay, from the lowest: compound 4; then compounds 2 and 3 (each within the scatter of the next); then compound 1.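

In this assay, adding one more hydroxy to the ring gives a 6.3-fold lower number from compound 2 to compound 4 (0.80 log units; beyond the scatter) and so shows that this ring position still responds to substitution, which the bromo-bearing compound 3 had not shown. Among the compounds shown here, the 3,4-dihydroxyphenyl group also separates from the 5-bromo-2-hydroxyphenyl group, with a 7.6-fold lower number from compound 3 to compound 4 (0.88 log units; beyond the scatter) as the printed step, and the full replacement of 4-nitrophenyl gives a 25-fold lower number from compound 1 to compound 4 (1.40 log units; beyond the scatter) as the largest step so far. Nothing available explains this gain. On these data alone, whether the gain needs both free hydroxy groups remains open. So does whether methoxy groups or an amine on the ring would keep it.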